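Methoxycarbonyl to ethoxycarbonyl: expected step for compound 4

The compounds below may be only part of what the source reports. "The series", "measured", "known", "first", "only" and "open" are said of these compounds alone.

In a functional assay on the whole organism for agonist activity, with Mus musculus as the target (on this read-out higher numbers stand for an effect only at larger amounts of compound and lower numbers for an effect already at smaller amounts), compound 1 (`COC(=O)N(C)CC#CCN1CCCC1`) gives 5.5 mg/kg, compound 2 (`COC(=O)N(C)C(C)C#CCN1CCCC1`) gives 14.2 mg/kg and compound 3 (`COC(=O)N(C)C(C)C#CCN(C)C`) gives 17.3 mg/kg. Compound 2 therefore stands within the scatter of compound 3 and at a higher number than compound 1.

Compound 4 (`CCOC(=O)N(C)C(C)C#CCN1CCCC1`) differs from compound 2 by methyl in place of hydrogen on a saturated chain carbon bound to an oxygen next to a carbonyl group, so methoxycarbonyl becomes ethoxycarbonyl.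

Going by the values given here, no measured step touches this place. The closest comparison is the other methyl in place of hydrogen, a 2.6-fold higher number from compound 1 to compound 2 (0.41 log units; beyond the scatter), which is modest but sits on a saturated chain carbon bound to an amide-type nitrogen and a triple-bonded carbon. The change from pyrrolidin-1-yl to dimethylamino, a 1.2-fold higher number from compound 2 to compound 3 (0.09 log units; within the scatter), lies elsewhere too. A small move toward a higher number is expected, no larger than the modest methyl step. The expected step is a 1.5-fold higher number from compound 2 to compound 4 (0.19 log units; within the scatter). For compound 4 the estimated value is 22 mg/kg, with an expected range from 9 mg/kg to 55 mg/kg.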

Compound 4, dose for half-maximal effect: > 100 mg/kg
Compound 4 ended at the assay's limit (the forecaster's own chance of this, stated with the estimate: 15%); middle value at least 4.5-fold (0.65 log units) from the limit.
By their numbers in this assay, from the lowest: compound 1; then compounds 2 and 3 (each within the scatter of the next). At a limit, above all of these: compound 4.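

In this assay compound 4 stands at a limit of the assay, > 100 mg/kg, and not at a measured number. Methyl in place of hydrogen on a saturated chain carbon bound to an oxygen next to a carbonyl group, the change from methoxycarbonyl to ethoxycarbonyl, gives an at least 7.0-fold higher number from compound 2 to compound 4 (0.84 log units; beyond the scatter), so this place responds strongly to the change, which the earlier steps could not show, as the methyl step a 2.6-fold higher number from compound 1 to compound 2 (0.41 log units; beyond the scatter) sits elsewhere. Only a lower bound on the size of this step can be read, since compound 4 sits at the end of the range: the limit of > 100 mg/kg in this assay, at which 1 of the 4 values shown sits.

The compounds shown leave open how a longer chain such as propoxycarbonyl, or a ring-bearing group such as benzyloxycarbonyl, reads at this place. Also open, as far as these compounds go, is whether ethoxycarbonyl gives the same result with dimethylamino in place of pyrrolidin-1-yl.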